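The source may report more compounds than this note shows. Statements on the series, on what has been measured and on what is new or still open speak of the compounds shown alone.

Working notes on the series in an ADME assay on HOS cells (Homo sapiens) for cytotoxicity; on this read-out higher numbers stand for lower toxicity in this test and lower numbers for higher toxicity in this test. Compound 1 (`CN1CCC(n2c(CN(C)C3CCCc4cccnc43)nc3ccccc32)CC1`) gives 16000 nM, compound 2 (`CN1CC(Cn2c(CN(C)C3CCCc4cccnc43)nc3ccccc32)C1`) gives 14000 nM and compound 3 (`CN1CCC(Cn2c(CN(C)C3CCCc4cccnc43)nc3ccccc32)C1`) gives 15000 nM. Compound 3 thus stands level with the other two, as all three values lie within the scatter of one another.

The next step leads to compound 4 (`CN(Cc1nc2ccccc2n1CC1CNC1)C1CCCc2cccnc21`): azetidin-3-yl in place of 1-methylpyrrolidin-3-yl on a saturated chain carbon bound to an aromatic nitrogen. The closest measured step is a 1.1-fold higher number from compound 2 to compound 3 (0.03 log units; within the scatter), which exchanges the same two ring sizes with the 1-methyl group kept. The changes of the whole substituent are equally small: a 1.1-fold lower number from compound 1 to compound 2 (0.06 log units; within the scatter), and a 1.1-fold lower number from compound 1 to compound 3 (0.03 log units; within the scatter). All three measured compounds carry a 1-methyl group on that ring, whereas azetidin-3-yl has none, so the data hold no step for its removal, and the range is kept wide for that reason.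

The expected step is a 1.3-fold lower number from compound 3 to compound 4 (0.10 log units; within the scatter), with no change beyond the scatter anticipated in this assay. Compound 4 is estimated at 12000 nM, with an expected range of 6000 nM to 22000 nM.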

Compound 4, half-maximal cytotoxic concentration: 15000 nM
Compound 4: the middle estimate sits 1.3-fold (0.10 log units) below what was measured; the range from low to high includes it.
By their numbers in this assay, from the lowest: compounds 2, 3, 4 and 1 (each within the scatter of the next).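

In this assay the series now includes a ring amine without its methyl group, and hydrogen in place of methyl on that nitrogen gives a direct reading (a 1.1-fold higher number from compound 2 to compound 4 (0.03 log units; within the scatter)). Azetidin-3-yl in place of 1-methylpyrrolidin-3-yl also leaves the read-out within the scatter (no change at the digits printed from compound 3 to compound 4 (within the scatter)), as does (azetidin-3-yl)methyl in place of 1-methylpiperidin-4-yl (a 1.1-fold lower number from compound 1 to compound 4 (0.03 log units; within the scatter)), so in these four compounds neither the ring size nor the methyl group on the ring nitrogen separates the values. No supporting data bear on this result.

From the compounds shown here alone, it remains open whether an acetyl or benzyl group on the ring nitrogen would stay within the same scatter. The same question stands for a cyclobutyl ring, which has no nitrogen, in that place.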